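Amide in place of urea: expected return toward weaker growth inhibition

This account rests on a few compounds, and the source may have more. Where it says the series, first, only, none or still open, it means among the compounds named here.

Measured compounds:
compound 1 `COc1cc(-c2nn(-c3cccc(NC(=O)c4cccc(C(F)(F)F)c4)c3)cc2-c2ccncc2)ccc1Cl` gives 32500 nM
compound 2 `COc1cc(-c2nn(-c3cccc(NC(=O)Nc4ccc(Cl)c(Cl)c4)c3)cc2-c2ccncc2)ccc1Cl` gives 5190 nM
compound 3 `COc1cc(-c2nn(-c3cccc(NC(=O)Nc4cccc(C(F)(F)F)c4)c3)cc2-c2ccncc2)ccc1Cl` gives 3410 nM

All three were tested in a functional assay on NCI-H23 cells (Homo sapiens) for inhibition, read by sulforhodamine B assay, with a stated time of 48 h; on this read-out lower numbers stand for stronger inhibition of growth and higher numbers for weaker inhibition of growth. Compound 3 holds the lowest number of the three; its nearest neighbour is compound 2, and the two lie within the scatter of each other, so no order between them can be claimed. Compound 1 sits well apart: the step of a 9.5-fold lower number from compound 1 to compound 3 (0.98 log units; beyond the scatter) and the step of a 6.3-fold lower number from compound 1 to compound 2 (0.80 log units; beyond the scatter) both run in the same direction, while a 1.5-fold lower number from compound 2 to compound 3 (0.18 log units; within the scatter) changes little.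

Compound 4 `COc1cc(-c2nn(-c3cccc(NC(=O)c4ccc(Cl)c(C(F)(F)F)c4)c3)cc2-c2ccncc2)ccc1Cl` carries 4-chloro-3-(trifluoromethyl)phenyl in place of (3-(trifluoromethyl)phenyl)amino on a carbonyl carbon. This is essentially the reverse of the step from compound 1 to compound 3, with a chlorine added on the aryl ring; the step of a 1.5-fold lower number from compound 2 to compound 3 (0.18 log units; within the scatter) suggests that such a ring substitution alters little. The main bearing therefore comes from the step of a 9.5-fold lower number from compound 1 to compound 3 (0.98 log units; beyond the scatter), now expected to be undone.

Compound 4 is expected to show a 7.3-fold higher number from compound 3 to compound 4 (0.87 log units; beyond the scatter). For compound 4 the estimate in this assay is 25000 nM, with a range from 8000 nM to 70000 nM.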

Compound 4, concentration for total growth inhibition: > 32500 nM
Compound 4 ended at the assay's limit (the forecaster's own chance of this, stated with the estimate: 10%); middle value at least 1.3-fold (0.11 log units) away from the limit.
By their numbers in this assay, from the lowest: compounds 3 and 2 (each within the scatter of the next); then compound 1.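

For compound 4 the result in this assay is a limit of the assay and not a number: the limit of > 32500 nM in this assay, at which 1 of the 4 values shown sits.

With a second amide, the gap to the ureas holds for a different aryl ring on the carbonyl carbon: the change gives an at least 9.5-fold higher number from compound 3 to compound 4 (0.97 log units; beyond the scatter) and an at least 6.2-fold higher number from compound 2 to compound 4 (0.79 log units; beyond the scatter). Among the four compounds, both ureas therefore give lower numbers than the amide compound 4, and no compound here goes against this. From the compounds shown here alone, the step that puts chloro in place of hydrogen on an aromatic carbon gives a number no lower from compound 1 to compound 4 (the limit leaves the size open); it cannot be read, so the effect of that chloro remains unknown.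

The compounds shown do not separate the role of the urea nitrogen from that of its hydrogen. A methyl group on that nitrogen, or a carbamate oxygen in its place, would bear on this question.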